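The compounds below may be only part of what the source reports. "The series", "measured", "known", "first", "only" and "open" are said of these compounds alone.

Working notes on the series. In an ADME assay on cells (Peritoneal macrophage cell, Mus musculus) for cytotoxicity, read by fluorescence and resazurin assay, with a stated time of 3 days (on this read-out lower numbers stand for higher toxicity in this test and higher numbers for lower toxicity in this test), compound 1 `N#Cc1ccc(C2CCN(C(=O)Nc3cc(-c4ccccn4)n[nH]3)CC2)cc1` gives > 64000 nM, which is a limit of the assay and not a number. Compound 2 `O=C(NCc1ccccc1)Nc1[nH]nc(-c2ccccn2)c1C1CC1` gives > 45000 nM in this assay, and this too is a limit. Compound 1 therefore stands only as a limit, and no order can be read between the two compounds.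

Compound 3 `O=C(Nc1cc(-c2ccccn2)n[nH]1)N1CCC(Oc2ccccn2)CC1` keeps the core of compound 1 and carries (pyridin-2-yl)oxy in place of 4-cyanophenyl on a saturated ring carbon of the six-membered non-aromatic ring with 1 nitrogen ((pyridin-2-yl)oxy in place of 4-cyanophenyl on a saturated ring carbon).

Within the data shown here, no two measured compounds differ in one place, so no measured step is available as a guide. The expectation rests on compound 1, whose limit is > 64000 nM. The expected step of an at least 1.0-fold lower number from compound 1 to compound 3 (0.02 log units; that floor lies within the scatter) in this assay is none beyond the scatter, in either direction. A report of compound 3 as a limit again would be no surprise. For compound 3 the estimated value is 60000 nM, with an expected range from 25000 nM to 100000 nM.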

Compound 3, half-maximal cytotoxic concentration: > 64000 nM
Compound 3: only a limit was reported (the forecaster's own chance of this, stated with the estimate: 75%); middle value at least 1.0-fold (0.02 log units) from the limit.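

Compound 3 gives > 64000 nM in this assay, which is a limit of the assay and not a number. Compound 1 and compound 3 both stand only as limits, so no step can be read between them. The compounds shown leave open where the half-maximal cytotoxic concentration of any of them lies.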